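A few compounds are considered here, and "the series" means these few. Any claim that something is new, unique, unknown or untested is made for them only; others in the source may bear on it.

Of the compounds shown here, three built on one shared core have been measured in an assay on HEK293 cells for displacement of a labelled ligand from Neuronal acetylcholine receptor; alpha4/beta2 (Homo sapiens), read by scintillation counting, with a stated time of 120 min; on this read-out higher numbers stand for weaker inhibition and lower numbers for stronger inhibition. Compound 1 `Fc1cccc(-c2cn([C@@H]3CN4CCC3CC4)nn2)c1` gives 519 nM. Compound 2 `Fc1ccc(COc2cccc(-c3cn([C@@H]4CN5CCC4CC5)nn3)c2)cc1`, which carries a (4-fluorobenzyl)oxy group in place of the fluoro group on the aromatic carbon, gives 537 nM; the step of a 1.0-fold higher number from compound 1 to compound 2 (0.01 log units; within the scatter) lies within the scatter, so these two compounds cannot be told apart on this read-out. Compound 3 `FCCCOc1cccc(-c2cn([C@H]3CN4CCC3CC4)nn2)c1` gives 9010 nM, the highest of the three numbers and beyond the scatter from both compound 1 and compound 2.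

Compound 4 `FCCCOc1cccc(-c2cn([C@@H]3CN4CCC3CC4)nn2)c1` has not yet been measured. It differs from compound 3 in no atom or bond: the two compounds have the same atoms and bonds; at least one stereo element is drawn with a configuration in one of them and without one in the other: 1 of 3 stereo elements differ; a stereocentre at a saturated ring carbon is drawn R in compound 3 and S in compound 4. Drawn with the same configuration at that ring carbon as compound 4 are compound 1, which gives 519 nM, and compound 2, which gives 537 nM; both stand well below compound 3. Among the compounds with values here, no measured step in this set isolates that stereocentre on its own, so the comparison rests only on what these values show. On that basis compound 4 is expected to give a clearly lower number than compound 3, a step of a 13-fold lower number from compound 3 to compound 4 (1.11 log units; beyond the scatter). The estimate for compound 4 is 700 nM, with a range from 200 nM to 3000 nM.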

Compound 4, inhibition constant: 1980 nM
For compound 4 the middle estimate is 2.8-fold (0.45 log units) below the measured one; the range from low to high includes it.
By their numbers in this assay, from the lowest: compounds 1 and 2 (each within the scatter of the next); then compound 4; then compound 3.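

In this assay, within the data shown here, the configuration at the saturated ring carbon has a measurable effect of its own: in the only pair here that isolates this stereocentre, the step is a 4.6-fold lower number from compound 3 to compound 4 (0.66 log units; beyond the scatter), which is modest but beyond the scatter. With that carbon drawn S, the group on the aromatic ring also registers, giving a 3.8-fold higher number from compound 1 to compound 4 (0.58 log units; beyond the scatter) and a 3.7-fold higher number from compound 2 to compound 4 (0.57 log units; beyond the scatter), although fluoro and (4-fluorobenzyl)oxy could not be told apart in a 1.0-fold higher number from compound 1 to compound 2 (0.01 log units; within the scatter); the 3-fluoropropoxy group therefore stands modestly above both, even though a much larger group left the number unchanged. The stereo reading rests on this single pair and carries one caution: the fact that one of compounds 3 and 4 is drawn with a defined configuration and the other without, at the place where they differ.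

On these data alone, whether changing this stereocentre has a similar effect when fluoro or (4-fluorobenzyl)oxy sits on the aromatic carbon remains open. Also open, as far as these compounds go, is what a hydroxyl group, an amine or a longer chain would give in place of the 3-fluoropropoxy group, so these few compounds do not establish a trend for this position.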